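Adding one chloro to compound 3: what to expect

The compounds below may be only part of what the source reports. "The series", "measured", "known", "first", "only" and "open" are said of these compounds alone.

In an ADME assay on MT4 cells (Homo sapiens) for inhibition, read by MTT assay, with a stated time of 5 days (on this read-out lower numbers stand for higher toxicity in this test and higher numbers for lower toxicity in this test), compound 1 `Cc1cccc(C)c1Oc1cc(Nc2ccc(C#N)cc2)ncc1[N+](=O)[O-]` gives 126000 nM, compound 2 `Cc1cc(Br)cc(C)c1Oc1cc(Nc2ccc(C#N)cc2)ncc1[N+](=O)[O-]` gives 12300 nM, and compound 3 `N#Cc1ccc(Nc2cc(Oc3c(Cl)cccc3Cl)c([N+](=O)[O-])cn2)cc1` gives 27700 nM, the middle of the three numbers. Compound 4 `N#Cc1ccc(Nc2cc(Oc3c(Cl)cc(Cl)cc3Cl)c([N+](=O)[O-])cn2)cc1` differs from it by one change: chloro in place of hydrogen on an aromatic carbon. This is chloro in place of hydrogen on an aromatic carbon, turning 2,6-dichlorophenyl into 2,4,6-trichlorophenyl. Going by the values given here, the closest precedent is bromo in place of hydrogen on an aromatic carbon, a large step: a 10-fold lower number from compound 1 to compound 2 (1.01 log units; beyond the scatter). That is a single pair with a different halogen, so a smaller step in the same direction, towards higher toxicity, is expected. The expected step is a 3.1-fold lower number from compound 3 to compound 4 (0.49 log units; beyond the scatter). Compound 4 is estimated at 9000 nM, with an expected range of 3000 nM to 26000 nM.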

Compound 4, half-maximal cytotoxic concentration: 16200 nM
Estimate against measurement, compound 4: 1.8-fold (0.26 log units) below; the measured number falls inside the stated range.
By their numbers in this assay, from the lowest: compounds 2, 4 and 3 (each within the scatter of the next, the first and the last beyond it); then compound 1.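

In this assay, the chloro added para to a large group on the 2,6-dichlorophenyl ring gives a 1.7-fold lower number from compound 3 to compound 4 (0.23 log units; within the scatter) and so has no readable effect here, unlike the bromo step on the dimethyl ring. The two 4-halogenated rings cannot be told apart, with a 1.3-fold higher number from compound 2 to compound 4 (0.12 log units; within the scatter) as the step between them. Compound 1 remains the least toxic in this test, with a 7.8-fold lower number from compound 1 to compound 4 (0.89 log units; beyond the scatter) as its step to the trichloro compound. Going by these compounds, whether an amine or a methoxy group at this place would shift the number stays open. Nothing available explains these numbers.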